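Cytotoxicity Outlook for an Oxazole Replacing a Nitrile

The compounds below may be only part of what the source reports. "The series", "measured", "known", "first", "only" and "open" are said of these compounds alone.

Of the compounds shown here, three built on one shared core have been tested in an ADME assay on PC-3 cells (Homo sapiens) for cytotoxicity, read by WST assay, tested at 100 uM; on this read-out higher numbers stand for more inhibition at the one concentration tested (going by the name of the read-out) and lower numbers for less inhibition. Compound 1 `Cc1nc(-c2cccc(NC(=O)C3CCCN(C(=O)c4cc(C(F)(F)F)cc(C(F)(F)F)c4)C3)c2)cs1` gives 1%. Compound 3 `CCc1cccc(NC(=O)C2CCCN(C(=O)c3cc(C(F)(F)F)cc(C(F)(F)F)c3)C2)c1` gives 0%, and the change from compound 1 to compound 3, ethyl in place of 2-methyl-1,3-thiazol-4-yl on an aromatic carbon, comes with a number 1 percentage points lower from compound 1 to compound 3 (within the scatter). Compound 2 `N#Cc1cccc(C(=O)N2CCCC(C(=O)Nc3ccc(Cl)cc3)C2)c1` gives 0%, the same digits as compound 3, and the value of compound 1 lies within the scatter of it.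

Compound 4 `O=C(Nc1ccc(Cl)cc1)C1CCCN(C(=O)c2cccc(-c3cnco3)c2)C1` has not yet been measured in this assay. Compared with compound 2 it carries 1,3-oxazol-5-yl in place of cyano on an aromatic carbon. For the measured compounds named here, the only measured step, from compound 1 to compound 3, swaps one group on an aromatic carbon and stays within the scatter; no measured step swaps a cyano for a five-membered aromatic ring. Since all three measured values sit near the bottom of the scale, a move beyond the scatter is not expected. Compound 4 is therefore expected to give 2%, within a range from 0% to 15%, meaning an expected step of a number 2 percentage points higher from compound 2 to compound 4 (within the scatter).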

Compound 4, a percentage reported as inhibition, at one concentration (the size of the read-out at that concentration, not a potency): 0%
The estimate for compound 4 lay 2 percentage points above the measured number, and the stated range covers the measured number.
By their numbers in this assay, from the lowest: compounds 2, 3, 4 and 1 (each within the scatter of the next).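

In this assay, exchanging the cyano group for 1,3-oxazol-5-yl on the six-membered aromatic ring, meta to a large group, comes with no change at the digits printed from compound 2 to compound 4 (within the scatter). The earlier compounds shown here held no step at this place, and here a group of 2 heavy atoms with no ring gives way to one of 5 heavy atoms with a five-membered aromatic ring, without the read-out moving beyond the scatter. No measurement on hand offers an explanation for this result.

None of the compounds shown has a number clear of the scatter of the others, so it stays unknown whether any change at this place can shift the read-out. An amine or a carboxylic acid in this place, for example, remains an open case.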